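Chloro in place of ethyl on the ring of compound 2

The source may report more compounds than this note shows. Statements on the series, on what has been measured and on what is new or still open speak of the compounds shown alone.

Measured so far:
compound 1 `CCc1ccccc1NC(=O)N[C@H](C)c1ccccc1` gives 100%
compound 2 `CCc1cccc(NC(=O)N[C@H](C)c2ccccc2)c1` gives 71%
compound 3 `CCc1cccc(NC(=O)N[C@@H](C)c2ccccc2)c1` gives 94%

These three ureas were run in an ADME assay on the whole organism with Oryza sativa as the target, tested at 1 uM; on this read-out higher numbers stand for a weaker effect at the one concentration tested and lower numbers for a stronger effect. Compound 2 stands lowest of the three, with compound 3 nearest and compound 1 furthest. Among the compounds with values here, the only step between two compounds that differ in one place is the one from compound 2 to compound 3, a number 23 percentage points higher from compound 2 to compound 3 (beyond the scatter), and it rests on (the fact that compounds 2 and 3 differ only in the configuration as drawn), the two being the same in every atom and bond. Within the data shown here, compound 1 and compound 2 differ in where the ethyl sits, and no step is given for that pair; their values alone show compound 1 at the top.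

Compound 4 `C[C@@H](NC(=O)Nc1cccc(Cl)c1)c1ccccc1` has not yet been measured. It differs from compound 2 by chloro in place of ethyl on an aromatic carbon. Among the measured compounds shown here, no measured step changes a substituent on that ring, so none bears directly on this change, and the one step known concerns configuration, not the group on the ring. The estimate for compound 4 therefore stays near compound 2: an expected 75%, with a range from 55% to 100%, meaning an expected step of a number 4 percentage points higher from compound 2 to compound 4 (within the scatter) that is not expected to go beyond the scatter.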

Compound 4, a percentage reported as activity, at one concentration (the size of the read-out at that concentration, not a potency): 91%
Compound 4: middle estimate off by 16 percentage points, on the low side; the range from low to high includes it.
By their numbers in this assay, from the lowest: compound 2; then compounds 4, 3 and 1 (each within the scatter of the next).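

In this assay, chloro in place of ethyl on this aromatic carbon, meta to a large group, gives a number 20 percentage points higher from compound 2 to compound 4 (beyond the scatter), a weaker effect at the one concentration tested. This shows that the group on the ring moves the read-out with the configuration held as drawn, whereas the earlier step within the scatter-exceeding range concerned configuration alone. The change takes away 2 heavy atoms and puts in 1 heavy atom, with no ring, hydrogen-bond donor, hydrogen-bond acceptor or net charge on either side, and nothing at hand accounts for the step.

The compounds shown leave open whether a methyl, a methoxy, a longer chain or an amine on the same aromatic carbon would fall nearer compound 2 or nearer compound 4 in this assay. They also leave open whether configuration still matters with chloro on the ring, since a number 23 percentage points higher from compound 2 to compound 3 (beyond the scatter) is a step known only with ethyl in place.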